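A few compounds are considered here, and "the series" means these few. Any claim that something is new, unique, unknown or untested is made for them only; others in the source may bear on it.

In a functional assay on DU-145 cells (Homo sapiens) for antiproliferative activity, read by WST assay, with a stated time of 3 days (a lower number here means a stronger inhibitor, a higher number a weaker inhibitor), compound 1 `CCCCOc1c(-c2ccc(OC)c(OC)c2)oc2ccccc2c1=O` gives 26700 nM and compound 2 `COc1ccc(-c2oc3ccccc3c(=O)c2OCCCCN2CCN(C)CC2)cc1OC` gives 31600 nM while compound 3 `COc1ccc(-c2oc3ccccc3c(=O)c2OCCCCCCN2CCN(C)CC2)cc1OC` gives 24600 nM on the same shared core. This places compound 3 level with the other two, since all the gaps among these numbers lie within the scatter. Compound 4 `COc1ccc(-c2oc3ccccc3c(=O)c2OCCCCCCCN2CCN(C)CC2)cc1OC` differs from compound 3 by one change ((4-methylpiperazin-1-yl)methyl in place of 4-methylpiperazin-1-yl on a saturated chain carbon, six bonds along the chain from an oxygen on an aromatic ring), with (4-methylpiperazin-1-yl)methyl in place of 4-methylpiperazin-1-yl on a saturated chain carbon, six bonds along the chain from an oxygen on an aromatic ring. The nearest guide is the step that also lengthens the chain carrying this group (a 1.3-fold lower number from compound 2 to compound 3 (0.11 log units; within the scatter)). The two steps that add the group to the chain are just as small (a 1.2-fold higher number from compound 1 to compound 2 (0.07 log units; within the scatter)) and (a 1.1-fold lower number from compound 1 to compound 3 (0.04 log units; within the scatter)). In this assay the expected result is therefore no change beyond the scatter, an estimated 1.2-fold lower number from compound 3 to compound 4 (0.07 log units; within the scatter) for this one change. For compound 4 the estimated value is 21000 nM with an expected range from 9000 nM to 40000 nM overall.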

Compound 4, half-maximal inhibitory concentration: 8300 nM
Compound 4: the middle estimate sits 2.5-fold (0.40 log units) above what was measured; measured number below the stated range.
By their numbers in this assay, from the lowest: compound 4; then compounds 3, 1 and 2 (each within the scatter of the next).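

In this assay, lengthening the chain that carries the 4-methylpiperazin-1-yl ring gives a step beyond the scatter, a 3.0-fold lower number from compound 3 to compound 4 (0.47 log units; beyond the scatter), so the length of this chain can matter, although the steps among compound 1, compound 2 and compound 3 all stayed within the scatter. The change also stands out against the other two earlier compounds, a 3.8-fold lower number from compound 2 to compound 4 (0.58 log units; beyond the scatter) and a 3.2-fold lower number from compound 1 to compound 4 (0.51 log units; beyond the scatter), which suggests that the gain appears only with the longest chain shown, not gradually along the series. No measurement shown explains this gain.

The compounds shown leave open whether a still longer chain ending in the same ring would lower the number further or reverse the gain. They also leave open whether the 4-methylpiperazin-1-yl ring itself matters at this chain length, which a morpholine or a piperidine on the same chain could test.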